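A few compounds are considered here, and "the series" means these few. Any claim that something is new, unique, unknown or untested is made for them only; others in the source may bear on it.

Of the compounds shown here, two sharing one core have been tested in a functional assay (QGY7701 cells, Homo sapiens) for inhibition, read by MTT assay, with a stated time of 48 h; a lower number here means a stronger inhibitor, a higher number a weaker inhibitor. Compound 1 `COc1ccc(CNC(=O)/C=C/c2coc3cc(O)ccc3c2=O)cc1` gives 10000 nM. Compound 2 `COc1ccc2c(=O)c(/C=C/C(=O)Nc3ccccc3)coc2c1` gives 14000 nM. These two numbers lie within the usual scatter of each other, so neither compound can be called the stronger. Compound 3 `COc1ccc2c(=O)c(/C=C/C(=O)NCc3ccccc3F)coc2c1` keeps the core of compound 2 and changes only the amide substituent: 2-fluorobenzyl in place of phenyl on an amide-type nitrogen. Within the data shown here, no measured pair shows this exact change, so the expectation is a shift of a 1.6-fold lower number from compound 2 to compound 3 (0.19 log units; within the scatter), no larger than the scatter. Compound 3 is expected to give about 9000 nM, somewhere between 3000 nM and 25000 nM.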

Compound 3, half-maximal inhibitory concentration: 34000 nM
For compound 3 the middle estimate is 3.8-fold (0.58 log units) below the measured one; measured number above the stated range.
By their numbers in this assay, from the lowest: compounds 1 and 2 (each within the scatter of the next); then compound 3.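

In this assay, 2-fluorobenzyl in place of phenyl on the amide-type nitrogen gives a 2.4-fold higher number from compound 2 to compound 3 (0.39 log units; beyond the scatter) and so makes compound 3 the weaker inhibitor. This shows that the number does respond to the group at this position, though the step is modest. No measurement available here explains the rise.

The change adds both a fluorine and an extra carbon, and the compounds shown do not separate the two. On these data alone, whether plain benzyl, or a group carrying an amine or a carboxylic acid, would lower the number remains open.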